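Replacing bromo with methyl: what to expect for compound 3

This account rests on a few compounds, and the source may have more. Where it says the series, first, only, none or still open, it means among the compounds named here.

Measured in a functional assay on SK-OV-3 cells (Homo sapiens) for cytotoxicity; a lower number here means a stronger inhibitor of growth, a higher number a weaker inhibitor of growth:
Compound 1 `COc1ccc(C2=C(c3ccc(SC)cc3)CC3CCCN3C2=O)cc1O`: > 100000 nM
Compound 2 `COc1ccc(C2=C(c3ccc(SC)cc3)CC3CCCN3C2=O)cc1Br`: 3000 nM

The entry for compound 1, > 100000 nM, is a limit of the assay and not a number. Among the measured compounds shown here, compound 2, at 3000 nM, holds the only true number so far, so it cannot yet be ranked against another measured value. The next compound, compound 3 `COc1ccc(C2=C(c3ccc(SC)cc3)CC3CCCN3C2=O)cc1C`, changes one group: methyl in place of bromo on an aromatic carbon. For the measured compounds named here, one measured step bears on this place: an at least 33-fold lower number from compound 1 to compound 2 (1.52 log units; beyond the scatter), which is large. Its size rests on a limit: the limit of > 100000 nM in this assay, at which 1 of the 2 values shown sits. Bromo and methyl each count 0 hydrogen-bond donors and 0 hydrogen-bond acceptors, so in this assay no step beyond the scatter is expected, with a slight lean towards a higher number. The estimated step is a 1.3-fold higher number from compound 2 to compound 3 (0.12 log units; within the scatter). Compound 3 is expected at 4000 nM, with an estimated range of 1200 nM to 15000 nM.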

Compound 3, concentration for 50% growth inhibition: 15000 nM
Estimate against measurement, compound 3: 3.8-fold (0.57 log units) below; the range from low to high includes it.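

In this assay, bromo and methyl count the same heavy atoms, hydrogen-bond donors and acceptors, yet the swap gives a 5.0-fold higher number from compound 2 to compound 3 (0.70 log units; beyond the scatter), so those counts alone do not settle the outcome at this position. Methyl still does better than hydroxy, with an at least 6.6-fold lower number from compound 1 to compound 3 (0.82 log units; beyond the scatter), which puts the three groups in the order bromo, methyl, hydroxy from stronger to weaker inhibitor of growth. The true size of that last step stays unknown, since compound 1 stands at a limit and not a number: the limit of > 100000 nM in this assay, at which 1 of the 3 values shown sits.

The compounds shown do not tell why bromo gives a lower number than methyl. They also leave open where chloro, an amine or a longer chain such as ethyl would fall in this order at the same place.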